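This account rests on a few compounds, and the source may have more. Where it says the series, first, only, none or still open, it means among the compounds named here.

In a functional assay on MV4-11 cells (Homo sapiens) for inhibition, read by resazurin assay, with a stated time of 72 h (on this read-out higher numbers stand for weaker inhibition of growth and lower numbers for stronger inhibition of growth), compound 1 `O=C1NCCC12CCN(c1c(Cl)cncc1-c1ccc(Cl)s1)CC2` gives 560 nM and compound 2 `O=C1NCCC12CCN(c1c(Cl)cncc1-c1ccc(CN3CCCC3)s1)CC2` gives 3370 nM. Compound 2 therefore holds the higher of the two numbers, which makes it the weaker growth inhibitor of this pair. Compound 3 `O=C1NCCC12CCN(c1c(Cl)cncc1-c1ccc(CN3CCCCC3)s1)CC2` keeps the whole of compound 2 except for one group: piperidin-1-yl in place of pyrrolidin-1-yl on a saturated chain carbon bound to an aromatic carbon. In plain terms, piperidin-1-yl takes the place of pyrrolidin-1-yl on a saturated chain carbon bound to an aromatic carbon. For the measured compounds named here, the only measured step, a 6.0-fold higher number from compound 1 to compound 2 (0.78 log units; beyond the scatter), came with (pyrrolidin-1-yl)methyl in place of chloro on an aromatic carbon. That step is a much larger structural exchange and bears only indirectly, as it shows that this part of the molecule can shift the number. Going by the values given here, no measured pair tests a swap from one saturated ring to the other, so the data give no direction for it. The expected change is therefore small, a 1.1-fold lower number from compound 2 to compound 3 (0.05 log units; within the scatter), and no step beyond the scatter is anticipated. Compound 3 is estimated at 3000 nM, with an expected range of 1300 nM to 7000 nM.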

Compound 3, concentration for 50% growth inhibition: 4010 nM
Beside the measured number, compound 3's estimate is 1.3-fold (0.13 log units) below it, and the stated range covers the measured number.
By their numbers in this assay, from the lowest: compound 1; then compounds 2 and 3 (each within the scatter of the next).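

In this assay, moving from pyrrolidin-1-yl to piperidin-1-yl on a saturated chain carbon bound to an aromatic carbon gives a 1.2-fold higher number from compound 2 to compound 3 (0.08 log units; within the scatter), so this change of ring size has no effect that can be told apart from the ordinary variation between repeated measurements. Replacing chloro on the aromatic carbon with (piperidin-1-yl)methyl gives a 7.2-fold higher number from compound 1 to compound 3 (0.85 log units; beyond the scatter), which places a second ring-bearing group alongside the one in a 6.0-fold higher number from compound 1 to compound 2 (0.78 log units; beyond the scatter), and so the loss of growth inhibition relative to chloro no longer rests on a single compound. Nothing available here explains why these numbers fall as they do.

On these data alone, whether the insensitivity to ring size would hold for other groups at this carbon remains open, for example morpholin-4-yl, which has an oxygen atom in its ring, or an open-chain dimethylamino group. As far as these compounds go, it is equally open whether a longer chain between the aromatic carbon and the ring nitrogen, or a carboxylic acid in place of the amine, would bring the number closer to that of compound 1.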